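A few compounds are considered here, and "the series" means these few. Any claim that something is new, unique, unknown or untested is made for them only; others in the source may bear on it.

Compound 1, `Cc1cc(NC(=O)Nc2cccc([N+](=O)[O-])c2)c2ccccc2n1`: > 25000 nM
Compound 2, `Cc1cc(NC(=O)Nc2ccc(C(=O)O)cc2)c2ccccc2n1`: > 25000 nM
Compound 3, `Cc1cc(NC(=O)Nc2ccc(Cl)cc2Cl)c2ccccc2n1`: > 25000 nM

In an ADME assay on Raji cells (Homo sapiens) for cytotoxicity, with a stated time of 72 h (a higher number here means that more compound is needed for the effect, a lower number that less compound is needed), compound 1 gives > 25000 nM, which is a limit of the assay and not a number. Compound 2 likewise returns only a limit, > 25000 nM. Compound 3 also stays at a limit, > 25000 nM. Compound 1 therefore stands at the limit of > 25000 nM in this assay, at which 3 of the 3 values shown sit, and no order among the three compounds can be read from these values. Compound 4, `Cc1cc(NC(=O)Nc2cccc(C(C)(C)C)c2)c2ccccc2n1`, has not yet been measured. It differs from compound 1 in one place: tert-butyl in place of nitro on an aromatic carbon. Within the data shown here, no measured pair here differs in a single place, so no step size is at hand; in this assay no step beyond the scatter is expected, the value most likely remaining at the limit. Compound 4 is estimated at 30000 nM, within a range from 12000 nM to 100000 nM. The step this expectation implies is a step that the limit leaves unreadable from compound 1 to compound 4.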

Compound 4, half-maximal effective concentration: > 25000 nM
Compound 4: a limit, no number (the forecaster's own chance of this, stated with the estimate: 80%); the middle value does not contradict the limit.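

Among these compounds, compound 4, like compound 1, returns only a limit in this assay, so no step between compound 1 and compound 4 can be read: the limit of > 25000 nM in this assay, at which 4 of the 4 values shown sit. The compounds shown leave open whether any change on the shared core gives a readable value in this read-out.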